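Paw edema series: nitro for chloro on the aroyl ring

The source may report more compounds than this note shows. Statements on the series, on what has been measured and on what is new or still open speak of the compounds shown alone.

Measured compounds:
compound 1 `Nc1nc(CC(=O)O)n[nH]1`, 48.1%
compound 2 `CCOC(=O)Cc1n[nH]c(N)n1`, 51.8%
compound 3 `CCOC(=O)Cc1nc(N)n(C(=O)c2ccc(Cl)cc2)n1`, 62.8%

In a functional assay on the whole organism (strain albino) for inhibition, with Rattus norvegicus as the target, read by paw edema, with stated times of 30 min and 3 h, at a dose of 5 mg/kg by the oral route (a higher number here means more inhibition at the dose given (going by the name of the read-out), a lower number less inhibition), compound 3 gives the highest of the three numbers; the nearest is compound 2 with 51.8%, a gap beyond the scatter, and the furthest is compound 1 with 48.1%, also beyond the scatter. Going by the values given here, the one step between measured compounds that differ in one place, a number 3.7 percentage points higher from compound 1 to compound 2 (within the scatter), lies within the scatter and concerns the ester, not the aroyl ring.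

Compound 4 `CCOC(=O)Cc1nc(N)n(C(=O)c2ccc([N+](=O)[O-])cc2)n1` differs from compound 3 by nitro in place of chloro on an aromatic carbon. Among the compounds with values here, no measured step bears on this change: none of the measured compounds exchanges one group for another on that ring, and the ester step from compound 1 to compound 2 says nothing about it. With nothing to draw on, the expectation rests on the value of compound 3 alone, and no step beyond the scatter is expected in this assay in either direction.

Compound 4 is therefore estimated at 63%, within 48% to 78%, which is an expected step of a number 0.2 percentage points higher from compound 3 to compound 4 (within the scatter).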

Compound 4, a percentage reported as inhibition, in the whole organism at one dose (the size of the read-out at that dose, not a potency): 68.2%
For compound 4 the middle estimate is 5.2 percentage points below the measured one, within the range that was stated.
By their numbers in this assay, from the lowest: compounds 1 and 2 (each within the scatter of the next); then compounds 3 and 4 (each within the scatter of the next).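

In this assay the exchange on the aromatic ring gives a number 5.4 percentage points higher from compound 3 to compound 4 (within the scatter) at this carbon, para to a large group. Going by these compounds alone, this is the first step read on that ring: nitro, with three heavy atoms and two hydrogen-bond acceptors, takes the place of chloro, with one heavy atom and none, and the two compounds cannot be told apart in this read-out. Nothing measured here speaks to why the two groups read alike.

From the compounds shown here alone, whether an amine or a methoxy group on the same carbon would also fall within the scatter of these two remains open. Going by these compounds, both compounds carry the ethyl ester, so it is also open whether a carboxylic acid in its place would leave the same picture on the aroyl ring.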